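From methoxy to 2,2,2-trifluoroethoxy on compound 3

The source may hold more compounds than are shown below. What is called first, only, known or untested is meant among the compounds shown, and "the series" means these compounds.

Measured in a functional assay on HeLa cells (Homo sapiens) for antiproliferative activity, read by MTT assay, with a stated time of 48 h (on this read-out higher numbers stand for weaker inhibition and lower numbers for stronger inhibition), are these compounds.
Compound 1 `COc1cc(-c2nnc3c(OC)cc(-c4ccc5[nH]ccc5c4)cn23)cc(OC)c1OC` gives 85 nM.
Compound 2 `COc1cc(-c2nnc3c(OC)cc(-c4ccc5[nH]cc(C=O)c5c4)cn23)cc(OC)c1OC` gives > 10000 nM, which is a limit of the assay.
Compound 3 `COc1cc(-c2nnc3c(OC)cc(-c4ccc5c(ccn5C)c4)cn23)cc(OC)c1OC` gives 15 nM.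

Compound 3 holds the lower of the two values that are not limits. Compound 4 `COc1cc(-c2nnc3c(OCC(F)(F)F)cc(-c4ccc5c(ccn5C)c4)cn23)cc(OC)c1OC` differs from it by trifluoromethyl in place of hydrogen on a saturated chain carbon bound to an oxygen on an aromatic ring, so methoxy becomes 2,2,2-trifluoroethoxy. Within the data shown here, no measured step touches this place. The nearest guides lie elsewhere on the molecule and point in opposite directions: a 5.7-fold lower number from compound 1 to compound 3 (0.75 log units; beyond the scatter) is modest, and an at least 110-fold higher number from compound 1 to compound 2 (2.07 log units; beyond the scatter) is large. A modest rise is therefore expected in this assay, with the estimated step being a 3.3-fold higher number from compound 3 to compound 4 (0.52 log units; beyond the scatter). The estimate for compound 4 is 50 nM, with an expected range of 12 nM to 300 nM.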

Compound 4, half-maximal inhibitory concentration: 199 nM
Beside the measured number, compound 4's estimate is 4.0-fold (0.60 log units) below it; the range from low to high includes it.
By their numbers in this assay, from the lowest: compound 3; then compound 1; then compound 4. At a limit, above all of these: compound 2.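

The group on this oxygen is not a neutral place on the shared core: in this assay, methoxy to 2,2,2-trifluoroethoxy gives a 13-fold higher number from compound 3 to compound 4 (1.12 log units; beyond the scatter). Among these compounds, this is the first measured change at this position, and it shows that trifluoromethyl in place of hydrogen on this saturated chain carbon is not tolerated without a large loss. Nothing measured here speaks to the cause of this step.

Whether the trifluoromethyl itself or simply the longer chain accounts for the loss stays open, and plain ethoxy, with no fluorine, would separate the two. From the compounds shown here alone, how a hydroxyl or an amine would fare at this place is also open.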